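The source may hold more compounds than are shown below. What is called first, only, known or untested is meant among the compounds shown, and "the series" means these compounds.

Measured compounds:
compound 1 `CCCC(=O)Nc1cccc(NC(=O)COc2ccc3c(=O)ccoc3c2)c1` — 1430 nM
compound 2 `N#Cc1ccc(C(=O)Nc2cccc(NC(=O)COc3ccc4c(=O)ccoc4c3)c2)cc1` — 123 nM
compound 3 `CC(C)(C)c1cc(C(=O)Nc2cccc(NC(=O)COc3ccc4c(=O)ccoc4c3)c2)no1` — 101 nM

All three share one core and differ only in the group on the outer carbonyl carbon. In an assay on isolated protein for inhibition of Rho-associated protein kinase 1 (Homo sapiens), read by scintillation counting, radiometric assay and 33P incorporation, with a stated time of 40 min, in the presence of a further agent that is not named here (a higher number here means a weaker inhibitor, a lower number a stronger inhibitor), compound 3 gives the lowest number of the three, but it sits within the scatter of compound 2 (a 1.2-fold lower number from compound 2 to compound 3 (0.09 log units; within the scatter)), so no order between them can be read. Both ring-bearing groups stand well clear of the propyl of compound 1 (a 12-fold lower number from compound 1 to compound 2 (1.07 log units; beyond the scatter); a 14-fold lower number from compound 1 to compound 3 (1.15 log units; beyond the scatter)).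

Compound 4 `Cc1nc(C(=O)Nc2cccc(NC(=O)COc3ccc4c(=O)ccoc4c3)c2)cs1` carries the change (2-methyl-1,3-thiazol-4-yl in place of 5-(tert-butyl)-1,2-oxazol-3-yl on a carbonyl carbon). Both aromatic groups measured so far behave alike, and the thiazolyl amide is a third ring-bearing group, so no step beyond the scatter is expected in this assay (a 1.8-fold higher number from compound 3 to compound 4 (0.25 log units; within the scatter)). For compound 4 the expected value is 180 nM, range 60 nM to 600 nM.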

Compound 4, half-maximal inhibitory concentration: 473 nM
Beside the measured number, compound 4's estimate is 2.6-fold (0.42 log units) below it; measured number inside the range.
By their numbers in this assay, from the lowest: compounds 3 and 2 (each within the scatter of the next); then compound 4; then compound 1.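

At this position on the carbonyl carbon, a ring-bearing group alone does not hold the number in this assay: 2-methyl-1,3-thiazol-4-yl falls behind both earlier groups (a 4.7-fold higher number from compound 3 to compound 4 (0.67 log units; beyond the scatter)) (a 3.8-fold higher number from compound 2 to compound 4 (0.58 log units; beyond the scatter)), yet it stays clear of propyl (a 3.0-fold lower number from compound 1 to compound 4 (0.48 log units; beyond the scatter)). The series therefore now has an intermediate level. Nothing measured here accounts for this loss.

From the compounds shown here alone, whether the ring or its substituent carries the step remains open. The 2-(tert-butyl)-1,3-thiazol-4-yl group, on the same carbonyl carbon, would separate the two.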